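Three aryl thioureas measured; bromoacetamide tail to follow

The compounds below may be only part of what the source reports. "The series", "measured", "known", "first", "only" and "open" are said of these compounds alone.

Measured so far:
compound 1 `CCCn1c(=O)c2nc(-c3ccc(OCC(=O)NCCN=C(S)Nc4ccc(N=C=S)cc4)cc3)[nH]c2n(CCC)c1=O`: 6.6 nM
compound 2 `CCCn1c(=O)c2nc(-c3ccc(OCC(=O)NCCN=C(S)Nc4ccc(C)cc4)cc3)[nH]c2n(CCC)c1=O`: 16 nM
compound 3 `CCCn1c(=O)c2nc(-c3ccc(OCC(=O)NCCN=C(S)Nc4ccc(S(=O)(=O)O)cc4)cc3)[nH]c2n(CCC)c1=O`: 367 nM

In an assay on brain for binding affinity to adenosine receptor A1 (Rattus norvegicus), read by radioligand binding (a higher number here means a weaker inhibitor, a lower number a stronger inhibitor), compound 2 stands second highest of the three numbers. The step from compound 1 is modest, a 2.4-fold higher number from compound 1 to compound 2 (0.38 log units; beyond the scatter), while the sulfo analogue lies far off: a 23-fold higher number from compound 2 to compound 3 (1.36 log units; beyond the scatter), and from the other end a 56-fold higher number from compound 1 to compound 3 (1.75 log units; beyond the scatter). All three measured steps exchange only the substituent on the aromatic ring of the thiourea tail; none alters the tail itself.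

Compound 4 `CCCn1c(=O)c2nc(-c3ccc(OCC(=O)NCCNC(=O)CBr)cc3)[nH]c2n(CCC)c1=O` is the next case. The change from compound 2 is a group of 5 heavy atoms (2 carbon, 1 nitrogen, 1 oxygen, 1 bromine; no ring) in place of a group of 11 heavy atoms (8 carbon, 2 nitrogen, 1 sulfur; one six-membered aromatic ring of carbon only), on a saturated chain carbon, two bonds along the chain from an amide-type nitrogen. Going by the values given here, no measured step covers this kind of change, so the expectation rests on the fact that the shared core with its phenoxyacetamide linker gave strong numbers in compound 1 and compound 2 whatever the tail carried, except for sulfo. A step within the scatter or a modest weakening is therefore expected for compound 4, worded as a 1.6-fold higher number from compound 2 to compound 4 (0.19 log units; within the scatter). The estimate for compound 4 in this assay is 25 nM, expected between 6 nM and 100 nM.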

Compound 4, inhibition constant: 17.6 nM
Beside the measured number, compound 4's estimate is 1.4-fold (0.15 log units) above it; the measured number falls inside the stated range.
By their numbers in this assay, from the lowest: compound 1; then compounds 2 and 4 (each within the scatter of the next); then compound 3.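

In this assay the step is a 1.1-fold higher number from compound 2 to compound 4 (0.04 log units; within the scatter) when the whole aryl thiourea group gives way to ((bromomethyl)carbonyl)amino on a saturated chain carbon, two bonds along the chain from an amide-type nitrogen. The earlier steps shown here changed only the substituent on the aromatic ring, whereas this one shows that, for this pair, neither that ring nor the thiourea is needed to hold the number at this level. Nothing available explains why the two tails read alike.

An acetyl amide or a free amine at this chain end would test whether the bromine contributes anything to the number. A longer chain carrying the same ((bromomethyl)carbonyl)amino group would show how far the result depends on the length of the linker.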